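This account rests on a few compounds, and the source may have more. Where it says the series, first, only, none or still open, it means among the compounds named here.

Values in an ADME assay on MRC5 cells (Homo sapiens) for cytotoxicity, read by fluorescence, with a stated time of 24 h (on this read-out lower numbers stand for stronger inhibition and higher numbers for weaker inhibition), so far:
Compound 1 (`CCC1S/C(=N\N=C\c2c(-c3ccccc3)[nH]c3ccccc23)NC1=O`) > 50000 nM (a limit of the assay)
Compound 2 (`O=C1N/C(=N/N=C/c2c(-c3ccc(Br)cc3)[nH]c3ccccc23)SC1CCO`) 15900 nM
Compound 3 (`CCC1S/C(=N\N=C\c2c(-c3ccc([N+](=O)[O-])cc3)[nH]c3ccccc23)NC1=O`) 25200 nM

Compound 3 and compound 2 lie within the scatter of each other, and the only other entry is a limit. Compound 4 (`CCC1S/C(=N\N=C\c2c(-c3ccc(Cl)cc3)[nH]c3ccccc23)NC1=O`) departs from compound 3 by chloro in place of nitro on an aromatic carbon. Among the compounds with values here, the one measured step that bears on this is an at least 1.9-fold lower number from compound 1 to compound 3 (0.29 log units; that floor lies within the scatter), with nitro in place of hydrogen, and it starts from the limit of > 50000 nM in this assay, at which 1 of the 3 values shown sits. Compound 2 carries bromo and also differs in its chain, so it gives only loose support at 15900 nM. The expected change is small, within the scatter: a 1.1-fold lower number from compound 3 to compound 4 (0.06 log units; within the scatter). Compound 4 is estimated at 22000 nM, with an expected range from 11000 nM to 45000 nM.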

Compound 4, half-maximal inhibitory concentration: 8800 nM
The estimate for compound 4 lay 2.5-fold (0.40 log units) above the measured number; measured number outside the range, below it.
By their numbers in this assay, from the lowest: compounds 4, 2 and 3 (each within the scatter of the next, the first and the last beyond it). At a limit, above all of these: compound 1.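

In this assay, the aromatic carbon para to a large group responds to which group sits there, not merely to whether one does: 4-nitrophenyl to 4-chlorophenyl gives a 2.9-fold lower number from compound 3 to compound 4 (0.46 log units; beyond the scatter). Chloro in place of hydrogen gives an at least 5.6-fold lower number from compound 1 to compound 4 (0.75 log units; beyond the scatter), a step that clears the scatter, whereas the nitro step's floor did not: an at least 1.9-fold lower number from compound 1 to compound 3 (0.29 log units; that floor lies within the scatter). This chloro step starts from compound 1, whose entry is a limit and not a number: the limit of > 50000 nM in this assay, at which 1 of the 4 values shown sits.

Compound 2 differs in two places, so bromo cannot be read alone. On these data alone, how an amine or a methoxy group at this carbon would read remains open.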